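This account rests on a few compounds, and the source may have more. Where it says the series, first, only, none or still open, it means among the compounds named here.

Compound 1 `O=C(CSc1nc(Nc2ccccc2)c2ccccc2n1)Nc1ccccc1F` gives 9350 nM in a functional assay on NCI-H1975 cells (Homo sapiens) for inhibition, read by MTT assay, with a stated time of 72 h; on this read-out lower numbers stand for stronger inhibition and higher numbers for weaker inhibition; compound 2 `O=C(CSc1nc(Nc2ccccc2)c2ccccc2n1)Nc1ccc(Cl)cc1` gives 8040 nM; compound 3 `C=CC(=O)Nc1cccc(NC(=O)CSc2nc(Nc3ccccc3Cl)c3ccccc3n2)c1` gives 10000 nM.

Compound 3 carries the highest of the three numbers, yet its gaps to compound 1 and to compound 2 both lie within the scatter, so none of the three can be set apart from the others. Compound 4 `C=CC(=O)Nc1cccc(NC(=O)CSc2nc(Nc3cccc(C)c3)c3ccccc3n2)c1` differs from compound 3 by 3-methylphenyl in place of 2-chlorophenyl on a nitrogen on an aromatic ring. Among the measured compounds shown here, the one measured step, a 1.2-fold lower number from compound 1 to compound 2 (0.07 log units; within the scatter), concerns the amide-type nitrogen rather than the nitrogen on the aromatic ring, so no measured step bears directly on this change, and that step itself stayed within the scatter. One therefore expects no step beyond the scatter in this assay, a 1.1-fold lower number from compound 3 to compound 4 (0.02 log units; within the scatter). Compound 4 is estimated at 9500 nM, with a range from 4000 nM to 25000 nM.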

Compound 4, half-maximal inhibitory concentration: 12100 nM
The estimate for compound 4 lay 1.3-fold (0.11 log units) below the measured number; the measured number falls inside the stated range.
By their numbers in this assay, from the lowest: compounds 2, 1, 3 and 4 (each within the scatter of the next).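

Among the compounds shown here, the step of a 1.2-fold higher number from compound 3 to compound 4 (0.08 log units; within the scatter) in this assay gives this position, a nitrogen on an aromatic ring, its only measured change. It shows that 3-methylphenyl in place of 2-chlorophenyl, with the heavy-atom count unchanged, does not shift the number beyond the scatter. Nothing measured here accounts for this result.

Going by these compounds, only these two groups have been compared at this nitrogen, so the reach of the position stays open. A carboxylic acid or an amine on that phenyl ring, or a longer chain in its place, might still move the number beyond the scatter.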